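Fluorocyclopropyl amides: turning one ring stereocentre

The compounds below may be only part of what the source reports. "The series", "measured", "known", "first", "only" and "open" are said of these compounds alone.

Compound 3 `O=C([C@@H]1C[C@@H]1F)N1CC2CC(C1)N2` gives the lowest of the three numbers in an assay on SH-EP1 cells for agonist activity at Neuronal acetylcholine receptor; alpha4/beta2 (Homo sapiens), read by FLIPR and calcium flux (on this read-out lower numbers stand for an effect already at smaller amounts and higher numbers for an effect only at larger amounts of compound), namely 120 nM. Compound 2 `O=C([C@H]1C[C@H]1F)N1CC2CC(C1)N2` sits close to it, at 210 nM in this assay; between them a 1.8-fold lower number from compound 2 to compound 3 (0.24 log units; within the scatter). Compound 1 `CC(C)C(=O)N1CC2CC(C1)N2` lies far off with 19000 nM in this assay, so that a 160-fold lower number from compound 1 to compound 3 (2.20 log units; beyond the scatter) and a 90-fold lower number from compound 1 to compound 2 (1.96 log units; beyond the scatter). The move to compound 4 `O=C([C@@H]1C[C@H]1F)N1CC2CC(C1)N2` is again purely a matter of configuration: the two compounds have the same atoms and bonds; at least one stereo element is drawn with a configuration in one of them and without one in the other: 1 of 4 stereo elements differ; a stereocentre at a saturated ring carbon is drawn S in compound 3 and R in compound 4. Among the compounds with values here, the only measured step of the same kind, a 1.8-fold lower number from compound 2 to compound 3 (0.24 log units; within the scatter), stayed within the scatter, while the large steps came from exchanging the group on the carbonyl carbon, which does not change here. A shift in this assay of a 1.8-fold higher number from compound 3 to compound 4 (0.26 log units; within the scatter) is therefore expected, with a value for compound 4 estimated at 220 nM (range 60 nM to 800 nM).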

Compound 4, half-maximal effective concentration: 120 nM
The estimate for compound 4 lay 1.8-fold (0.26 log units) above the measured number, and the stated range covers the measured number.
By their numbers in this assay, from the lowest: compounds 3, 4 and 2 (each within the scatter of the next); then compound 1.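

Turning this one ring stereocentre in this assay gives no change at the digits printed from compound 3 to compound 4 (within the scatter) and a 1.8-fold lower number from compound 2 to compound 4 (0.24 log units; within the scatter) so no configuration tested here moves the number beyond the scatter among compounds 2, 3 and 4. The large step away from isopropyl holds for a third configuration of the 2-fluorocyclopropyl group, with a 160-fold lower number from compound 1 to compound 4 (2.20 log units; beyond the scatter) in this assay as well. One caution applies to the stereocentre comparison: the fact that one of compounds 3 and 4 is drawn with a defined configuration and the other without, at the place where they differ.

On these data alone, whether the fluorine or the cyclopropyl ring carries the large step stays open. So does the effect of an unsubstituted cyclopropyl or a 2,2-difluorocyclopropyl group on the carbonyl carbon.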